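Two Measured Analogues and One Still to Be Tested

A few compounds are considered here, and "the series" means these few. Any claim that something is new, unique, unknown or untested is made for them only; others in the source may bear on it.

Compound 2 `CN(C(=O)NC(=O)c1ccc(F)c(F)c1)c1nc(C(F)(F)F)c(C(=O)N/N=C/c2cc(C(F)(F)F)cc(C(F)(F)F)c2)s1` holds the lowest of the two numbers recorded so far in a functional assay on HeLa cells (Homo sapiens) for inhibition, read by MTT assay, with a stated time of 72 h (on this read-out lower numbers stand for stronger inhibition and higher numbers for weaker inhibition), where compound 2 gives 4.45 ug/mL. Its nearest neighbour is compound 1 `CN(C(=O)NC(=O)c1ccccc1F)c1nc(C(F)(F)F)c(C(=O)N/N=C/c2cccc(C(F)(F)F)c2)s1`, which in this assay gives 19.1 ug/mL, a gap that lies beyond the usual scatter. Compound 1 and compound 2 differ in more than one place. Their two values alone are what can be read from them. Compound 3 `CN(C(=O)NC(=O)c1ccccc1F)c1nc(C(F)(F)F)c(C(=O)N/N=C/c2cc(C(F)(F)F)cc(C(F)(F)F)c2)s1` has not yet been measured. It departs from compound 2 in a single place: 2-fluorophenyl in place of 3,4-difluorophenyl on a carbonyl carbon. Compound 3 thus carries the same group on its carbonyl carbon as compound 1 while keeping the rest of compound 2 unchanged. Going by the values given here, with no single step of this kind recorded, compound 3 is expected to land between the two measured numbers, a step of a 1.8-fold higher number from compound 2 to compound 3 (0.25 log units; within the scatter) toward weaker inhibition. Compound 3 is estimated at 8 ug/mL, with a range from 3 ug/mL to 20 ug/mL.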

Compound 3, half-maximal inhibitory concentration: 4.98 ug/mL
Compound 3: middle estimate off by 1.6-fold (0.21 log units), on the high side; the measured number falls inside the stated range.
By their numbers in this assay, from the lowest: compounds 2 and 3 (each within the scatter of the next); then compound 1.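

With 2-fluorophenyl in place of 3,4-difluorophenyl on a carbonyl carbon, this assay records a 1.1-fold higher number from compound 2 to compound 3 (0.05 log units; within the scatter), so these two groups cannot be told apart at this position, although they differ in their fluorine count. The other single change, trifluoromethyl in place of hydrogen on an aromatic carbon, gives a 3.8-fold lower number from compound 1 to compound 3 (0.58 log units; beyond the scatter), which shows that this change alone accounts for a step beyond the scatter, one that the comparison of compound 1 with compound 2 could not isolate. No measurement at hand explains either outcome.

On these data alone, it remains open whether this carbonyl position would stay as undemanding with a plain phenyl, a methoxyphenyl or a carboxylic acid on the ring. As far as these compounds go, it is equally open whether a chlorine or a nitrile on that aromatic carbon would give a step like the trifluoromethyl one.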